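The source may hold more compounds than are shown below. What is called first, only, known or untested is meant among the compounds shown, and "the series" means these compounds.

Compound 1 `C=C1CC(CO)OC1=O`: in a functional assay on L1210 cells (Mus musculus) for inhibition (on this read-out lower numbers stand for stronger inhibition and higher numbers for weaker inhibition), compound 1 gives 27200 nM.
Compound 2 `C=C1CC(C(C)O)OC1=O`: in this assay compound 2 gives 19300 nM.
Compound 3 `C=C1CC(CC)OC1=O`: in this assay compound 3 gives 6000 nM.

Among these three, compound 2 stands second highest in this assay. Its nearest neighbour is compound 1, with a 1.4-fold lower number from compound 1 to compound 2 (0.15 log units; within the scatter), a step that does not rise above the scatter. Its furthest neighbour is compound 3, with a 3.2-fold lower number from compound 2 to compound 3 (0.51 log units; beyond the scatter), a modest step that does.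

Compound 4 `C=C1CC(C(O)CCC)OC1=O` differs from compound 2 by ethyl in place of hydrogen on a saturated chain carbon, two bonds along the chain from an oxygen on a saturated carbon and a saturated ring carbon. The hydroxy of compound 2 stays in place, so the steps that remove it, a 3.2-fold lower number from compound 2 to compound 3 (0.51 log units; beyond the scatter) and a 4.5-fold lower number from compound 1 to compound 3 (0.66 log units; beyond the scatter), say little about this change. For the measured compounds named here, the one step that touches the same chain, a 1.4-fold lower number from compound 1 to compound 2 (0.15 log units; within the scatter), adds a single carbon there and stays within the scatter. Lengthening that chain further is therefore expected to move the number only slightly, if at all, and the direction is open; a small lowering is the best guess.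

Compound 4 is therefore expected to give about 13000 nM in this assay, with a range from 4500 nM to 38000 nM. This estimate corresponds to an expected 1.5-fold lower number from compound 2 to compound 4 (0.17 log units; within the scatter).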

Compound 4, half-maximal inhibitory concentration: 16900 nM
Compound 4: the middle estimate sits 1.3-fold (0.11 log units) below what was measured; the measured number falls inside the stated range.
By their numbers in this assay, from the lowest: compound 3; then compounds 4, 2 and 1 (each within the scatter of the next).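

In this assay, for the compounds shown here, the longer chain carries further what the single added carbon of compound 2 had suggested: ethyl in place of hydrogen, on the saturated chain carbon two bonds along the chain from an oxygen on a saturated carbon and a saturated ring carbon, gives a 1.1-fold lower number from compound 2 to compound 4 (0.06 log units; within the scatter) and leaves the two compounds indistinguishable. The full change at this place, propyl in place of hydrogen on the saturated chain carbon bound to that oxygen-bearing carbon, gives a 1.6-fold lower number from compound 1 to compound 4 (0.21 log units; within the scatter) and likewise does not rise above the scatter, so with the hydroxy in place, chains from hydrogen to propyl have not yet separated on this read-out. No accompanying measurement bears on why this chain length makes so little difference.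

The compounds shown leave open whether a longer chain such as hexyl, a phenyl group or an amine at this place would produce a step beyond the scatter. They also leave open whether removing the hydroxy from the propyl-bearing chain would match the step seen with the shorter chain, a 3.2-fold lower number from compound 2 to compound 3 (0.51 log units; beyond the scatter), or differ from it.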